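A few compounds are considered here, and "the series" means these few. Any claim that something is new, unique, unknown or untested is made for them only; others in the source may bear on it.

Compound 1, `Cc1nn(C)c2c1C(c1cccc(Cl)c1)=NCCN2C`, gives 0.63 mg/kg in a functional assay on the whole organism for positive allosteric modulation, with Rattus norvegicus as the target; on this read-out higher numbers stand for an effect only at larger amounts of compound and lower numbers for an effect already at smaller amounts.
Compound 2, `CCN1CCN=C(c2cccc(Cl)c2)c2c(C)nn(C)c21`, gives 0.63 mg/kg in this assay.
Compound 3, `Cc1nn(C)c2c1C(c1cccc(C(F)(F)F)c1)=NCCN2`, gives 0.63 mg/kg in this assay.

Compounds 1 and 2 differ by methyl in place of hydrogen on a saturated chain carbon bound to a nitrogen on an aromatic ring in a ring, and the step of no change at the digits printed from compound 1 to compound 2 (within the scatter) stays within the scatter. Compound 4, `CCn1nc(C)c2c1NCCN=C2c1cccc(C(F)(F)F)c1`, has not yet been measured in this assay; it differs from compound 3 by methyl in place of hydrogen on a saturated chain carbon bound to an aromatic nitrogen. The surroundings of the place are not worded alike for the two pairs: in the first pair the carbon is bound to a nitrogen on an aromatic ring in a ring, in the second to an aromatic nitrogen, so this is the same kind of change rather than the same change. The difference between the core of compound 1 and the core of compound 3 is not broken down here. Because no change at the digits printed from compound 1 to compound 2 (within the scatter) shows no change, the expected step for compound 4 is no change at the digits printed from compound 3 to compound 4 (within the scatter). Compound 4 is thus estimated at 0.63 mg/kg in this assay, expected to fall between 0.3 mg/kg and 1.3 mg/kg.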

Compound 4, minimum effective dose: 0.63 mg/kg
The estimate for compound 4 equals the measured number at the digits printed; low and high end bracket the measured number.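

On the core of compound 3, the step reads no change at the digits printed from compound 3 to compound 4 (within the scatter) in this assay. Set beside the earlier step, the two agree: the same change on two cores in this assay, no change at the digits printed (within the scatter) from compound 1 to compound 2 and no change at the digits printed (within the scatter) from compound 3 to compound 4, 1.0-fold (0.00 log units) apart, within the scatter of two such steps. So going from methyl to ethyl leaves the minimum effective dose unmoved on both cores, but these are only two pairs, the change sits in differently worded places (on a carbon bound to a nitrogen on an aromatic ring in a ring, and on a carbon bound to an aromatic nitrogen), and nothing here shows that it would carry to a third core.

Still open, on these data alone, is whether a longer chain such as propyl, or a chain bearing an amine or a carboxylic acid, would also leave the dose in place. The compounds shown stop at ethyl, so they cannot say how far this tolerance extends.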